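The source may report more compounds than this note shows. Statements on the series, on what has been measured and on what is new or still open speak of the compounds shown alone.

Going by the values given here, compound 3 `CCOC(=O)C1=C(N/N=C(/C(=O)Br)c2ccc(Cl)cc2)Nc2[nH]nc(C)c2C1c1ccc(N(C)C)cc1` sits second highest of the three numbers so far in a functional assay on HepG2 cells (Homo sapiens) for inhibition, read by MTT assay, with a stated time of 48 h; a higher number here means a weaker inhibitor, a lower number a stronger inhibitor: compound 3 gives 50300 nM, while compound 2 `CCOC(=O)C1=C(N/C=N/c2ccc([N+](=O)[O-])cc2)Nc2[nH]nc(C)c2C1c1ccc(N(C)C)cc1` gives 50900 nM and compound 1 `CCOC(=O)C1=C(NN=C(C(C)=O)C(C)=O)Nc2[nH]nc(C)c2C1c1ccc(N(C)C)cc1` gives 8480 nM. The step of a 5.9-fold higher number from compound 1 to compound 3 (0.77 log units; beyond the scatter) is beyond the scatter, as is a 6.0-fold higher number from compound 1 to compound 2 (0.78 log units; beyond the scatter), whereas a 1.0-fold lower number from compound 2 to compound 3 (0.01 log units; within the scatter) lies within it, so compound 2 and compound 3 cannot be ordered against each other.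

Compound 4 `CCOC(=O)C1=C(N/N=C(/Cl)c2ccc([N+](=O)[O-])cc2)Nc2[nH]nc(C)c2C1c1ccc(N(C)C)cc1` is reached from compound 3 by the change (a group of 12 heavy atoms (7 carbon, 2 nitrogen, 2 oxygen, 1 chlorine; one six-membered aromatic ring of carbon only) in place of a group of 12 heavy atoms (8 carbon, 1 nitrogen, 1 oxygen, 1 chlorine, 1 bromine; one six-membered aromatic ring of carbon only), on an amine nitrogen). The step that bears most closely on it is a 1.0-fold lower number from compound 2 to compound 3 (0.01 log units; within the scatter), in which the two aryl-bearing groups on the same amine nitrogen gave numbers within the scatter of each other; compound 4 carries a group that shares parts of both. Because a 1.0-fold lower number from compound 2 to compound 3 (0.01 log units; within the scatter) showed no movement, no step beyond the scatter is expected here, and the expected step is a 1.0-fold lower number from compound 3 to compound 4 (0.00 log units; within the scatter). Compound 4 is therefore estimated at 50000 nM in this assay, with a range from 20000 nM to 130000 nM.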

Compound 4, half-maximal inhibitory concentration: 55500 nM
Estimate against measurement, compound 4: 1.1-fold (0.05 log units) below; low and high end bracket the measured number.
By their numbers in this assay, from the lowest: compound 1; then compounds 3, 2 and 4 (each within the scatter of the next).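

In this assay, the group now on the amine nitrogen whose other neighbour is the double-bonded ring carbon leaves the number unmoved against both other aryl-bearing groups: a 1.1-fold higher number from compound 3 to compound 4 (0.04 log units; within the scatter) and a 1.1-fold higher number from compound 2 to compound 4 (0.04 log units; within the scatter) both lie within the scatter. Compound 4 therefore joins compound 2 and compound 3 as a third group with one six-membered aromatic ring of carbon only, and the exchange of bromine and one carbon for added nitrogen and oxygen shows no effect that can be read here. The gap to the ring-free group holds as well, with a 6.5-fold higher number from compound 1 to compound 4 (0.82 log units; beyond the scatter) beyond the scatter.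

The compounds shown leave open whether the lower number of compound 1 goes with the absence of a ring or with its two carbonyl groups, and how a plain alkyl chain or a carboxylic acid would read at this amine nitrogen. No measurement at hand speaks to the reason for these numbers.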